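Hydroxyphenyl pyridines on HCT-15: position of the hydroxyl

A few compounds are considered here, and "the series" means these few. Any claim that something is new, unique, unknown or untested is made for them only; others in the source may bear on it.

Of the compounds shown here, three have been measured in a functional assay on HCT-15 cells (Homo sapiens) for inhibition; a higher number here means a weaker inhibitor, a lower number a stronger inhibitor. Compound 1 `Oc1cccc(-c2cc(-c3cccc(C(F)(F)F)c3)cc(-c3cccc(O)c3)n2)c1` gives 13600 nM. Compound 2 `Oc1ccc(-c2cc(-c3cccc(C(F)(F)F)c3)cc(-c3cccc(O)c3)n2)cc1` gives 9540 nM in this assay, so the change 4-hydroxyphenyl in place of 3-hydroxyphenyl on an aromatic carbon made a 1.4-fold lower number from compound 1 to compound 2 (0.15 log units; within the scatter). Compound 3 `Oc1ccc(-c2cc(-c3cccc(OC(F)(F)F)c3)cc(-c3cccc(O)c3)n2)cc1` gives 1730 nM in this assay, and the change from compound 2 gave a 5.5-fold lower number from compound 2 to compound 3 (0.74 log units; beyond the scatter), the lowest number of the three.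

Compound 4 `Oc1ccc(-c2cc(-c3cccc(OC(F)(F)F)c3)cc(-c3ccc(O)cc3)n2)cc1` remains to be measured. It carries the change (4-hydroxyphenyl in place of 3-hydroxyphenyl on an aromatic carbon). This is the same kind of change as from compound 1 to compound 2, but not the same: there the place was meta to a 3-(trifluoromethyl)phenyl group and meta to a 3-hydroxyphenyl group, here it is meta to a 4-hydroxyphenyl group and meta to a large group. The difference between the two cores is not broken down here.

For compound 4 in this assay a step of about a 1.3-fold lower number from compound 3 to compound 4 (0.12 log units; within the scatter) is expected, resting on compound 1 and compound 2, where the same kind of change gave a 1.4-fold lower number from compound 1 to compound 2 (0.15 log units; within the scatter). Compound 4 is thus estimated at 1300 nM, within 500 nM to 3500 nM.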

Compound 4, half-maximal inhibitory concentration: > 50000 nM
Compound 4 gave a limit, no number; the forecaster's own chance of this, stated with the estimate: 0%; at least 38-fold (1.58 log units) between middle value and limit.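

In this assay compound 4 stands at > 50000 nM, which is a limit of the assay and not a number. The change of 4-hydroxyphenyl in place of 3-hydroxyphenyl did not carry over from one core to the other, with an at least 28-fold higher number from compound 3 to compound 4 (1.46 log units; beyond the scatter) set against the earlier step, and the two steps differ: the same change on two cores in this assay, a 1.4-fold lower number (0.15 log units; within the scatter) from compound 1 to compound 2 and an at least 28-fold higher number (1.46 log units; beyond the scatter) from compound 3 to compound 4, at least 41-fold (1.61 log units) apart, beyond the scatter of two such steps. This does not show how large the second step truly is, nor does it give a rule for the series, since each core supplies a single pair and the second step ends at a limit: the limit of > 50000 nM in this assay, at which 1 of the 4 values shown sits.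

Going by these compounds, it remains open whether the same loss appears on a trifluoromethyl core carrying two 4-hydroxyphenyl groups, or whether it depends on the trifluoromethoxy group. On these data alone, it also remains open whether a methoxy group, an amine or a carboxylic acid in place of the hydroxyl on one 4-hydroxyphenyl group would restore a measurable number.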